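Changing the acyl chain of compound 2

The source may report more compounds than this note shows. Statements on the series, on what has been measured and on what is new or still open speak of the compounds shown alone.

- In a functional assay on KYSE-450 cells (Homo sapiens) for inhibition, read by MTT assay, with a stated time of 48 h (on this read-out higher numbers stand for weaker inhibition and lower numbers for stronger inhibition), compound 1 `COc1ccc(CN(C(C)=O)c2cc(OC)c(OC)c(OC)c2)cc1O` gives 160 nM in the test.
- In this assay compound 2 `CC/C=C/C(=O)N(Cc1ccc(OC)c(O)c1)c1cc(OC)c(OC)c(OC)c1` gives 72 nM in the test.

Compound 2 has the lower of the two numbers, so it is the stronger inhibitor of this pair. The next compound, compound 3 `COc1ccc(CN(C(=O)CCCl)c2cc(OC)c(OC)c(OC)c2)cc1O`, carries 2-chloroethyl in place of but-1-en-1-yl on a carbonyl carbon. Going by the values given here, only one measured step bears on this change, the modest 2.2-fold lower number from compound 1 to compound 2 (0.35 log units; beyond the scatter), which also altered this group. One step is thin evidence, but a modest move back to a higher number is expected, estimated as a 1.8-fold higher number from compound 2 to compound 3 (0.26 log units; within the scatter) in this assay overall. For compound 3 the estimate is 130 nM with 50 nM to 320 nM as the expected range.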

Compound 3, half-maximal inhibitory concentration: 110 nM
The estimate for compound 3 lay 1.2-fold (0.07 log units) above the measured number; the measured number falls inside the stated range.
By their numbers in this assay, from the lowest: compounds 2, 3 and 1 (each within the scatter of the next, the first and the last beyond it).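

In this assay, this position on the carbonyl carbon accepts a saturated chain carrying chlorine: 2-chloroethyl in place of but-1-en-1-yl gives a 1.5-fold higher number from compound 2 to compound 3 (0.18 log units; within the scatter), so losing the double bond moves the number by no more than the scatter. Chloromethyl in place of hydrogen on the chain gives a 1.5-fold lower number from compound 1 to compound 3 (0.16 log units; within the scatter), so compound 3 cannot be told apart from either compound 1 or compound 2, although those two differ beyond the scatter. No measurement here offers a reason for these numbers.

Still open, going by these compounds, is how a plain propyl chain without chlorine would compare with compound 3. An amine or a carboxylic acid at the end of this chain also remains untested among the compounds shown.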